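The source may report more compounds than this note shows. Statements on the series, on what has been measured and on what is new or still open speak of the compounds shown alone.

Measured in a toxicity assay on THP-1 cells (Homo sapiens) for inhibition; on this read-out lower numbers stand for higher toxicity in this test and higher numbers for lower toxicity in this test:
- Compound 1 `COc1ccc(-c2cnc(NC(=O)c3cccc(O)c3)n2C)cc1`: > 100000 nM (a limit)
- Compound 2 `COc1ccc(-c2cnc(NC(=O)c3ccccc3Br)n2C)cc1`: > 100000 nM (a limit)
- Compound 3 `COc1ccc(-c2cnc(NC(=O)c3ccccn3)n2C)cc1`: > 100000 nM (a limit)

Compound 3 stands only at a limit, not at a number. All three compounds share this position, which is the limit of > 100000 nM in this assay, at which 3 of the 3 values shown sit. Compound 4 `COc1ccc(-c2cnc(NC(=O)c3ccccc3Cl)n2C)cc1` carries 2-chlorophenyl in place of pyridin-2-yl on a carbonyl carbon. The closest measured change is a step that the two limits leave unreadable from compound 2 to compound 3, and the other bearing on it is a step that the two limits leave unreadable from compound 1 to compound 3. Going by the values given here, neither has a readable size, so no measured step points to a change in this assay, and none beyond the scatter is expected. The expected change is a number no higher from compound 3 to compound 4 (the limit leaves the size open). For compound 4 the estimate is 100000 nM, with an expected range of 50000 nM to 200000 nM.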

Compound 4, half-maximal cytotoxic concentration: > 50000 nM
Compound 4 gave a limit, no number; the forecaster's own chance of this, stated with the estimate: 85%; the middle value is on the limit's open side.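

In this assay, going by these compounds alone, compound 1, compound 2, compound 3 and compound 4 all stand at limits and not at numbers, and no step among them can be read. The compounds shown leave open where any of their true values lies, and whether changing the group on the carbonyl carbon shifts toxicity in this test at all.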